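The compounds below may be only part of what the source reports. "The series", "measured", "known", "first", "only" and "open" are said of these compounds alone.

Measured so far in a physicochemical assay for solubility, at pH 7.4; a higher number here means a more soluble compound, a lower number a less soluble compound:
- Compound 1 `O=C(N[C@H]1CN(S(=O)(=O)c2ccccc2)C[C@@H]1C(=O)N[C@H]1CCCNC1)c1cc(C2CC2)n[nH]1`: 861000 nM
- Compound 2 `Cc1oc(-c2ccc(Cl)cc2)nc1C(=O)N[C@H]1CN(S(=O)(=O)c2ccccc2)C[C@@H]1C(=O)N[C@H]1CCCNC1`: 15000 nM

Of these two compounds, compound 1 stands highest in this assay, at 861000 nM. Compound 2 gives 15000 nM, a much lower number, and the gap between them lies beyond the scatter.

The account now turns to compound 3 `O=C(N[C@H]1CN(S(=O)(=O)c2ccccc2)C[C@@H]1C(=O)N[C@H]1CCCNC1)c1cc(-c2ccc(Cl)cc2)on1`, which has not yet been measured. It departs from compound 1 by one change on a carbonyl carbon, where 5-(4-chlorophenyl)-1,2-oxazol-3-yl takes the place of 3-cyclopropyl-1H-pyrazol-5-yl: 5-(4-chlorophenyl)-1,2-oxazol-3-yl in place of 3-cyclopropyl-1H-pyrazol-5-yl on a carbonyl carbon. For the measured compounds named here, no measured pair isolates this change, so the size of the step can only be judged loosely. The entering group is the larger of the two, and the only lower reference point is compound 2 at 15000 nM. A large downward step, well beyond the scatter, is therefore expected, and the estimated change is a 43-fold lower number from compound 1 to compound 3 (1.63 log units; beyond the scatter). For compound 3 the expected value is 20000 nM, with an estimated range from 5000 nM to 80000 nM.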

Compound 3, solubility: 12000 nM
For compound 3 the middle estimate is 1.7-fold (0.22 log units) above the measured one; the range from low to high includes it.
By their numbers in this assay, from the lowest: compounds 3 and 2 (each within the scatter of the next); then compound 1.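

In this assay, the group on this carbonyl carbon now has a measured step of its own: with 5-(4-chlorophenyl)-1,2-oxazol-3-yl in place of 3-cyclopropyl-1H-pyrazol-5-yl, the result is a 72-fold lower number from compound 1 to compound 3 (1.86 log units; beyond the scatter), a large change from a single exchange with the rest of the molecule held the same. For the compounds shown here, compound 1 and compound 2 had offered only two values side by side, whereas this pair shows directly that a change in this one place is enough to move the number well beyond the scatter, and it leaves compound 3 within the scatter of compound 2. Nothing measured in this account speaks to why the number moves as it does.

The compounds shown do not separate the parts of the entering group, since the five-membered ring and the 4-chlorophenyl arrive together, and either or both could account for the step. They also leave open how the number would respond on this carbonyl carbon to a plain phenyl without the chlorine, or to a group bearing an amine or a carboxylic acid.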